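A chlorophenyl swap on compound 3

The source may report more compounds than this note shows. Statements on the series, on what has been measured and on what is new or still open speak of the compounds shown alone.

In a functional assay on SiHa cells (Homo sapiens) for inhibition, read by sulforhodamine B assay (a higher number here means a weaker inhibitor of growth, a lower number a stronger inhibitor of growth), compound 3 `COc1ccc(-c2ccc(-c3ccc(-c4nc5ccccc5[nH]4)cc3)cc2)cc1` gives 2760 nM. Compound 1 `Cc1ccc2[nH]c(-c3ccc(-c4ccc(-c5cccc(Cl)c5)cc4)cc3)nc2c1` gives 3600 nM, within the scatter of that figure, while compound 2 `FC(F)(F)c1ccc(-c2ccc(-c3ccc(-c4nc5ccccc5[nH]4)cc3)cc2)cc1` gives a much higher 100000 nM. Compound 4 `Clc1cccc(-c2ccc(-c3ccc(-c4nc5ccccc5[nH]4)cc3)cc2)c1` has not yet been measured. It departs from compound 3 by 3-chlorophenyl in place of 4-methoxyphenyl on an aromatic carbon, which places 3-chlorophenyl in place of 4-methoxyphenyl on an aromatic carbon.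

Among the measured compounds shown here, the only measured step, a 36-fold lower number from compound 2 to compound 3 (1.56 log units; beyond the scatter), falls on the same ring and is large, so a change there can matter a great deal. The closer guide is compound 1, which already carries 3-chlorophenyl, has an extra methyl on the shared core, and stands at 3600 nM. On that reading, no shift beyond the scatter is expected. The expected change is a 1.2-fold higher number from compound 3 to compound 4 (0.08 log units; within the scatter). The large step seen with compound 2 keeps the range wide, especially towards higher numbers. For compound 4 the estimated value is 3300 nM, with an expected range of 1300 nM to 11000 nM.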

Compound 4, concentration for 50% growth inhibition: 100000 nM
The estimate for compound 4 lay 30-fold (1.48 log units) below the measured number, outside the stated range (above it).
By their numbers in this assay, from the lowest: compounds 3 and 1 (each within the scatter of the next); then compounds 2 and 4 (each within the scatter of the next).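

In this assay, 3-chlorophenyl does not hold the level of 4-methoxyphenyl on this aromatic carbon (a 36-fold higher number from compound 3 to compound 4 (1.56 log units; beyond the scatter)), and it cannot be told apart from 4-(trifluoromethyl)phenyl (no change at the digits printed from compound 2 to compound 4 (within the scatter)), so of the three groups compared here only 4-methoxyphenyl stands apart. The methyl on the shared core also counts once 3-chlorophenyl is in place (a 28-fold higher number from compound 1 to compound 4 (1.44 log units; beyond the scatter)), so compound 1 could not stand in for compound 4, and the effect of this group depends on what the core carries. No measurement offered here accounts for either step.

The compounds shown leave open whether the same methyl would matter alongside 4-methoxyphenyl. They also leave open whether an amine or a carboxylic acid on this ring would follow 4-methoxyphenyl or 3-chlorophenyl.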